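A Chloro Substituent on the Pyrazole of Compound 2

This account rests on a few compounds, and the source may have more. Where it says the series, first, only, none or still open, it means among the compounds named here.

compound 1 `C[C@@H]1CN(c2sc(C(F)(F)F)nc2-c2nc3cc(OCCO)ccc3[nH]2)CCN1C(=O)Cn1cnc2cccnc21`: 2.1 nM
compound 2 `C[C@@H]1CN(c2sc(C(F)(F)F)nc2-c2nc3ccccc3[nH]2)CCN1C(=O)Cn1cccn1`: 13 nM
compound 3 `Cc1nc(C)n(CC(=O)N2CCN(c3sc(C(F)(F)F)nc3-c3nc4ccc(C5CCOCC5)cc4[nH]3)C[C@H]2C)n1`: 3.3 nM

Three compounds share a core and were tested in a functional assay on CHO-K1 cells for antagonist activity at C-X-C chemokine receptor type 3 (Homo sapiens), read by FLIPR, with a stated time of 10 min, in the presence of a further agent that is not named here; on this read-out lower numbers stand for stronger inhibition and higher numbers for weaker inhibition. Compound 2 gives 13 nM, the highest number of the three; its gaps to compound 3 and to compound 1 both lie beyond the scatter, so compound 2 is the weakest inhibitor among them. Compound 4 `C[C@@H]1CN(c2sc(C(F)(F)F)nc2-c2nc3ccccc3[nH]2)CCN1C(=O)Cn1cc(Cl)cn1` has not yet been measured in this assay. It differs from compound 2 only in one place: chloro in place of hydrogen on an aromatic carbon. Among the compounds with values here, no measured pair shows the effect of such a change, so the expectation rests on compound 2 alone. Compound 4 is expected to show a small step, a 1.6-fold lower number from compound 2 to compound 4 (0.21 log units; within the scatter), toward a lower number, possibly not beyond the scatter. The estimate for compound 4 is 8 nM, within 3 nM to 25 nM.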

Compound 4, half-maximal inhibitory concentration: 1.7 nM
For compound 4 the middle estimate is 4.7-fold (0.67 log units) above the measured one; measured number outside the range, below it.
By their numbers in this assay, from the lowest: compounds 4, 1 and 3 (each within the scatter of the next); then compound 2.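

In this assay, chloro in place of hydrogen on the pyrazole gives a 7.6-fold lower number from compound 2 to compound 4 (0.88 log units; beyond the scatter), a step beyond the scatter. Within the data shown here, the earlier compounds offered no pair differing in one place, so this is the first sign that a single added atom on this aromatic carbon can shift the number this far. Nothing measured here accounts for the step.

From the compounds shown here alone, whether fluoro, methyl or a nitrile on the same carbon would give a similar step remains open. So does whether chloro would act alike on the pyrazole with a substituted benzimidazole-type partner, a question the compounds shown cannot settle.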